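Nitro in place of chloro: compound 2 to compound 4

The source may hold more compounds than are shown below. What is called first, only, known or untested is meant among the compounds shown, and "the series" means these compounds.

Compound 2 `O=C1/C(=C/c2ccccc2Cl)Cc2ccccc21` gives 128000 nM in a functional assay on Molt4/C8 cells (Homo sapiens) for inhibition (on this read-out lower numbers stand for stronger inhibition and higher numbers for weaker inhibition), a higher number than compound 1 `O=C1/C(=C/c2ccc(Cl)c(Cl)c2)CCCc2ccccc21`, which gives 18200 nM. Compound 3 `O=C1/C(=C/c2ccc(Cl)cc2Cl)Cc2ccccc21` sits at the assay limit (the limit of > 500000 nM in this assay, at which 1 of the 3 values shown sits), recorded as > 500000 nM. Among the measured compounds shown here, the step of an at least 3.9-fold higher number from compound 2 to compound 3 (0.59 log units; beyond the scatter) is the only measured change in this small set. Compound 4 `O=C1/C(=C/c2ccccc2[N+](=O)[O-])Cc2ccccc21` differs from compound 2 by nitro in place of chloro on an aromatic carbon. For the measured compounds named here, no measured step exchanges one substituent for another; the sole step concerns an added chloro and bears little on the present change. A step of about a 1.2-fold higher number from compound 2 to compound 4 (0.07 log units; within the scatter) is therefore expected, not beyond the scatter. Compound 4 is estimated at 150000 nM, within 50000 nM to 450000 nM.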

Compound 4, half-maximal inhibitory concentration: 2540 nM
Compound 4: the middle estimate sits 59-fold (1.77 log units) above what was measured; the measured number lies below the stated range.
By their numbers in this assay, from the lowest: compound 4; then compound 1; then compound 2. At a limit, above all of these: compound 3.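

In this assay the exchange of chloro for nitro gives a 50-fold lower number from compound 2 to compound 4 (1.70 log units; beyond the scatter), so the group on this aromatic carbon, ortho to a large group, can strongly lower the number. The earlier step concerned only an added chloro and went to a higher number, whereas this exchange shows that the series can also move sharply the other way. Nothing measured here accounts for the size of this step. Still open, going by these compounds, is how an amine or a carboxylic acid at this place would compare with nitro, and whether nitro also gives a lower number on the core of compound 1.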